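Stereoisomers of a hydroxylated pipecolic acid scaffold

The source may report more compounds than this note shows. Statements on the series, on what has been measured and on what is new or still open speak of the compounds shown alone.

Measured so far:
- compound 1 `O=C(O)[C@H]1NC[C@H](O)[C@H](O)[C@@H]1O`: 26%
- compound 2 `O=C(O)[C@H]1NC[C@H](O)[C@@H](O)[C@@H]1O`: 43%
- compound 3 `O=C(O)[C@@H]1NC[C@H](O)[C@@H](O)[C@H]1O`: 42%

In an assay on isolated protein for inhibition of cytosolic endo-beta-N-acetylglucosaminidase (Homo sapiens), tested at 1000 uM (on this read-out higher numbers stand for more inhibition at the one concentration tested (going by the name of the read-out) and lower numbers for less inhibition), compound 1 gives 26%, the lowest of the three numbers; compound 3 gives 42% and compound 2 gives 43%. Compound 4 `O=C(O)[C@@H]1NC[C@@H](O)[C@H](O)[C@H]1O` has not yet been tested in this assay. It differs from compound 1 as follows: the two compounds have the same atoms and bonds and differ only in configuration as drawn: 3 of 4 stereo elements differ; a stereocentre at a saturated ring carbon is drawn S in compound 1 and R in compound 4; a stereocentre at a saturated ring carbon is drawn S in compound 1 and R in compound 4; a stereocentre at a saturated ring carbon is drawn R in compound 1 and S in compound 4.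

The steps measured so far are all pure changes of configuration. Inverting a single stereocentre gave a number 17 percentage points higher from compound 1 to compound 2 (beyond the scatter), a change that rests on (the fact that compounds 1 and 2 differ only in the configuration as drawn). Inverting three stereocentres gave a number 16 percentage points higher from compound 1 to compound 3 (beyond the scatter), resting on (the fact that compounds 1 and 3 differ only in the configuration as drawn). Between the two reconfigured compounds the difference was a number 1 percentage points lower from compound 2 to compound 3 (within the scatter), consistent with the fact that compounds 2 and 3 differ only in the configuration as drawn. Compound 4 also inverts three stereocentres relative to compound 1, though not the same set as compound 3. With every measured reconfiguration raising the number modestly, a modest increase of similar size is expected, a number 12 percentage points higher from compound 1 to compound 4 (beyond the scatter), within the spread of the measured compounds. Compound 4 is therefore estimated at 38%, with a range from 15% to 60%.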

Compound 4, a percentage reported as inhibition, at one concentration (the size of the read-out at that concentration, not a potency): 50%
Compound 4: middle estimate off by 12 percentage points, on the low side, and the stated range covers the measured number.
By their numbers in this assay, from the lowest: compound 1; then compounds 3, 2 and 4 (each within the scatter of the next).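

In this assay, the result is a number 24 percentage points higher from compound 1 to compound 4 (beyond the scatter); a third set of inverted stereocentres thus also sets compound 1 apart, and no measured compound goes against this, with the step being purely one of configuration: the fact that compounds 1 and 4 differ only in the configuration as drawn

Compound 2 and compound 4 are mirror images, yet full inversion gives only a number 7 percentage points higher from compound 2 to compound 4 (within the scatter), so this read-out at its one concentration does not separate the pair. The remaining step, a number 8 percentage points higher from compound 3 to compound 4 (within the scatter), likewise puts no order on the three reconfigured compounds.

All the compounds shown share the same atoms and bonds, so whether a methyl ester or a primary amide in place of the carboxylic acid would keep the inhibition stays open. Also open, from the compounds shown here alone, is whether the gaps seen at the single concentration of this assay would hold as differences in potency.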